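A Methyl Step Repeated on a Second Sulfonamide Core

The source may report more compounds than this note shows. Statements on the series, on what has been measured and on what is new or still open speak of the compounds shown alone.

Compound 1 `CN(CCCn1cc[n+](C)c1/C=N/O)S(C)(=O)=O` gives -2.63 in a physicochemical assay for lipophilicity; on this read-out higher numbers stand for higher lipophilicity and lower numbers for lower lipophilicity. Compound 2 `CCN(CCCn1cc[n+](C)c1/C=N/O)S(C)(=O)=O` gives -2.69, and the step of a number 0.06 log units lower from compound 1 to compound 2 (within the scatter) comes from methyl in place of hydrogen on a saturated chain carbon bound to a sulfonamide nitrogen. Compound 3 `CCN(CCn1cc[n+](C)c1/C=N/O)S(=O)(=O)c1ccccc1` gives -1.39, a number beyond the scatter above compound 1 and compound 2; how its core differs from the core of compound 1 is not broken down here. Compound 4 `CCCN(CCn1cc[n+](C)c1/C=N/O)S(=O)(=O)c1ccccc1` has not been measured. It differs from compound 3 by methyl in place of hydrogen on a saturated chain carbon, two bonds along the chain from a sulfonamide nitrogen, the same kind of change as before, though the place differs: two bonds along the chain from a sulfonamide nitrogen rather than bound to it. Because a number 0.06 log units lower from compound 1 to compound 2 (within the scatter) stayed within the scatter, the expected step here is a number 0.14 log units higher from compound 3 to compound 4 (within the scatter). Compound 4 is therefore estimated at -1.25, between -1.7 and -0.8.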

Compound 4, distribution coefficient: -0.94
For compound 4 the middle estimate is 0.31 log units below the measured one; low and high end bracket the measured number.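

In this assay the methyl change on the core of compound 3 gives a number 0.45 log units higher from compound 3 to compound 4 (beyond the scatter) while on the core of compound 1 it gave a number 0.06 log units lower from compound 1 to compound 2 (within the scatter) at a different place on the chain. The step that stayed within the scatter on one core therefore has a counterpart beyond the scatter on the other, but this rests on a single pair for each core, and since both core and place differ, the two cannot be separated. Nothing measured here accounts for the result.

The compounds shown leave open what the same change does at one and the same place on both cores. They also leave open whether a butyl chain in place of the propyl of compound 4 would continue the step or an amine on that chain would reverse it.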